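A few compounds are considered here, and "the series" means these few. Any claim that something is new, unique, unknown or untested is made for them only; others in the source may bear on it.

Of the compounds shown here, three sharing one core have been measured in an assay for inhibition of Fatty-acid amide hydrolase 1 (Rattus norvegicus); on this read-out lower numbers stand for stronger inhibition and higher numbers for weaker inhibition. Compound 1 `CN(C)C(=O)c1cnc(C(=O)CCc2ccc(Oc3ccccc3)cc2)o1` gives 5.4 nM. Compound 2 `N#Cc1cccc(-c2cnc(C(=O)CCc3ccc(-c4ccccc4)cc3)o2)n1` gives 2.9 nM, and compound 3 `N#Cc1cccc(-c2cnc(C(=O)CCc3ccc(COc4ccccc4)cc3)o2)n1` gives 0.56 nM, the lowest of the three numbers. Within the data shown here, the only one-place step among them, a 5.2-fold lower number from compound 2 to compound 3 (0.71 log units; beyond the scatter), concerns the phenoxymethyl group and leaves the pyridine ring untouched. Compound 4 `O=C(O)c1ccc(-c2cnc(C(=O)CCc3ccc(COc4ccccc4)cc3)o2)nc1` differs from compound 3 by 5-carboxypyridin-2-yl in place of 6-cyanopyridin-2-yl on an aromatic carbon. Among the measured compounds shown here, no measured step alters this part of the structure, so there is no direct precedent for the direction or size of the change. The expected step is a 4.5-fold higher number from compound 3 to compound 4 (0.65 log units; beyond the scatter), a modest rise in the number. Compound 4 is therefore estimated in this assay at 2.5 nM, within a range from 0.4 nM to 15 nM.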

Compound 4, inhibition constant: 4.6 nM
Estimate against measurement, compound 4: 1.8-fold (0.26 log units) below; measured number inside the range.
By their numbers in this assay, from the lowest: compound 3; then compounds 2, 4 and 1 (each within the scatter of the next).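

In this assay the aromatic carbon next to the ring oxygen proves sensitive to the group it carries: 5-carboxypyridin-2-yl in place of 6-cyanopyridin-2-yl gives an 8.2-fold higher number from compound 3 to compound 4 (0.91 log units; beyond the scatter). This single step both replaces a nitrile with a carboxylic acid and changes the numbered place of that group on the pyridine ring, so the two changes cannot be told apart. No measurement here accounts for the rise. Still open, from the compounds shown here alone, is whether the acid itself or its place on the ring matters more. A 6-carboxypyridin-2-yl or 5-cyanopyridin-2-yl group would separate the two.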